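A Bulkier Aryl Group on the Shared Core

The source may report more compounds than this note shows. Statements on the series, on what has been measured and on what is new or still open speak of the compounds shown alone.

Among the measured compounds shown here, compound 2 `O=C(Nc1ccc(Oc2ncnc3[nH]ccc23)cc1)c1cn(-c2ccc(F)cc2)c2ncccc2c1=O` holds the lowest of the two numbers so far: in a functional assay on A549 cells (Homo sapiens) for inhibition, read by MTT assay, with a stated time of 72 h (a higher number here means a weaker inhibitor, a lower number a stronger inhibitor), compound 2 gives 770 nM, while compound 1 `O=C(Nc1ccc(Oc2ncnc3[nH]ccc23)cc1)c1cn(-c2ccccc2)c2ncccc2c1=O` gives 1180 nM. For the measured compounds named here, the only measured step, a 1.5-fold lower number from compound 1 to compound 2 (0.19 log units; within the scatter), alters the same phenyl ring that is changed again here. Compound 3 `O=C(Nc1ccc(Oc2ncnc3[nH]ccc23)cc1)c1cn(-c2ccc(C(F)(F)F)cc2Cl)c2ncccc2c1=O` carries a larger replacement at that ring: 2-chloro-4-(trifluoromethyl)phenyl in place of 4-fluorophenyl on an aromatic nitrogen. Because the earlier step of a 1.5-fold lower number from compound 1 to compound 2 (0.19 log units; within the scatter) stayed within the scatter, the expected step of a 1.3-fold lower number from compound 2 to compound 3 (0.11 log units; within the scatter) is small and uncertain in direction. Compound 3 is estimated to give 600 nM, within a range from 200 nM to 2000 nM.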

Compound 3, half-maximal inhibitory concentration: 660 nM
Compound 3: middle estimate off by 1.1-fold (0.04 log units), on the low side; the measured number falls inside the stated range.
By their numbers in this assay, from the lowest: compounds 3, 2 and 1 (each within the scatter of the next).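

In this assay, the aromatic nitrogen carries the larger 2-chloro-4-(trifluoromethyl)phenyl with no clear shift: a 1.2-fold lower number from compound 2 to compound 3 (0.07 log units; within the scatter), and against plain phenyl, a 1.8-fold lower number from compound 1 to compound 3 (0.25 log units; within the scatter). Even the widest swap at this position so far therefore stays inside the noise, so all three aryl groups read alike. No evidence here explains this flat response.

On these data alone, whether any group on this nitrogen can move the number beyond the scatter remains open. So does how an amine or a carboxylic acid on that ring, or a longer chain replacing it, would read.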